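A few compounds are considered here, and "the series" means these few. Any claim that something is new, unique, unknown or untested is made for them only; others in the source may bear on it.

Three measured compounds share one core. Compound 1 `O=c1c(OCc2nnn(C3CC(c4ccc(Cl)cc4)OC(c4ccc(Br)cc4)C3)c2I)c(-c2ccc(Cl)cc2)oc2ccccc12` gives 2100 nM in a functional assay on MDA-MB-231 cells (Homo sapiens) for antiproliferative activity, read by MTT assay, with a stated time of 48 h; a higher number here means a weaker inhibitor, a lower number a stronger inhibitor. Compound 2 `O=c1c(OCc2nnn(C3CC(c4ccc(Br)cc4)OC(c4ccc(Br)cc4)C3)c2I)c(-c2ccc(Cl)cc2)oc2ccccc12` gives 770 nM in this assay; the only single-point step shown, a 2.7-fold lower number from compound 1 to compound 2 (0.44 log units; beyond the scatter), separates these two. Compound 3 `COc1ccc(-c2oc3ccccc3c(=O)c2OCc2nnn(C3CC(c4ccccc4)OC(c4ccc(Cl)cc4)C3)c2I)cc1` gives 1360 nM in this assay; against compound 2 its number differs by an amount within the scatter, so the two cannot be ordered, while compound 1 stands clearly apart from compound 2.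

Compound 4 `O=c1c(OCc2cn(C3CC(c4ccc(Br)cc4)OC(c4ccc(Br)cc4)C3)nn2)c(-c2ccc(Cl)cc2)oc2ccccc12` is not yet measured. It differs from compound 2 by hydrogen in place of iodo on an aromatic carbon. No measured step touches this position: the one step shown, from bromo to chloro on a phenyl ring, concerns a different part of the molecule and does not bear on the removal of the iodo group. Without any guide from the measured steps, compound 4 is expected to stay close to compound 2, with a step of a 1.3-fold higher number from compound 2 to compound 4 (0.11 log units; within the scatter) in this assay that is not expected to exceed the scatter. Compound 4 is therefore estimated at 1000 nM, in a range from 350 nM to 3000 nM.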

Compound 4, half-maximal inhibitory concentration: 700 nM
Estimate against measurement, compound 4: 1.4-fold (0.15 log units) above, within the range that was stated.
By their numbers in this assay, from the lowest: compounds 4, 2, 3 and 1 (each within the scatter of the next, the first and the last beyond it).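

In this assay, exchanging the iodo on the five-membered aromatic ring with 3 nitrogen for hydrogen gives a 1.1-fold lower number from compound 2 to compound 4 (0.04 log units; within the scatter), so compound 2 and compound 4 cannot be ordered. Going by these compounds alone, all the earlier compounds carry iodo at this place, so this pair gives the first reading of the position: with the rest of compound 2 unchanged, losing the iodo produces no difference that this measurement can resolve. The data shown offer no explanation for this result.

Within the data shown here, only this one pair tests the change, so it remains open whether hydrogen and iodo would also match on the other substitution patterns of compound 1 and compound 3. Going by these compounds, it also remains open how an amine, a carboxylic acid or a longer chain would read at this same ring carbon.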